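Pyrrolidinone series: cytotoxicity on swapping the N-aryl group

The source may hold more compounds than are shown below. What is called first, only, known or untested is meant among the compounds shown, and "the series" means these compounds.

The shared core carries a cyclopentyloxy-methoxyphenyl group and an N-aryl group on the ring amide nitrogen, as in compound 1 `COc1ccc([C@H]2CC(=O)N(c3cccc(O)c3)C2)cc1OC1CCCC1`. In a functional assay on HEK293 cells (Homo sapiens) for cytotoxicity (a lower number here means that less compound is tolerated, a higher number that more compound is tolerated), compound 1 gives > 10000 nM, which is a limit of the assay and not a number. Compound 2 `COc1ccc([C@H]2CC(=O)N(c3cc(N)cc(N)c3)C2)cc1OC1CCCC1` gives > 10000 nM in this assay, again a limit. Compound 3 `COc1ccc([C@H]2CC(=O)N(c3cccc(C(F)(F)F)c3)C2)cc1OC1CCCC1` gives > 10000 nM, also a limit. The steps from compound 1 to compound 2 a step that the two limits leave unreadable from compound 1 to compound 2, from compound 1 to compound 3 a step that the two limits leave unreadable from compound 1 to compound 3 and from compound 2 to compound 3 a step that the two limits leave unreadable from compound 2 to compound 3 thus cannot be sized; all that is seen is the limit of > 10000 nM in this assay, at which 3 of the 3 values shown sit.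

Compound 4 `COc1ccc([C@H]2CC(=O)N(c3cccnc3)C2)cc1OC1CCCC1` differs from compound 1 only at the N-aryl group: pyridin-3-yl in place of 3-hydroxyphenyl on an amide-type nitrogen in a ring. For the measured compounds named here, none of the measured steps can be read, so no direction can be taken from them; what bears on the expectation is that every variation of this N-aryl group so far sits at the same limit, compound 1 at > 10000 nM included. Compound 4 is therefore expected to sit at or near that limit as well, with the step from compound 1 to compound 4 estimated as a step that the limit leaves unreadable from compound 1 to compound 4. The estimate for compound 4 in this assay is 20000 nM, with a range of 8000 nM to 60000 nM.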

Compound 4, half-maximal cytotoxic concentration: > 10000 nM
Compound 4 was reported as a limit; the forecaster's own chance of this, stated with the estimate: 85%; the middle value does not contradict the limit.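

In this assay compound 4 gives > 10000 nM, which is a limit and not a number. Its steps from compound 1, compound 2 and compound 3 therefore cannot be read, and all four compounds share one limit: the limit of > 10000 nM in this assay, at which 4 of the 4 values shown sit.

The compounds shown leave open how far these N-aryl groups differ in cytotoxicity, and whether any N-aryl group on the shared core gives a readable value.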